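Moving a Side Chain Around a Ring: Compound 4

The source may report more compounds than this note shows. Statements on the series, on what has been measured and on what is new or still open speak of the compounds shown alone.

Measured so far:
- compound 1, `CC#C[C@@H](Cc1nnn[nH]1)c1ccc(OCc2ccc3sc(F)c(-c4ccccc4C)c3c2)cc1`: 15 nM
- compound 2, `CC#C[C@@H](Cc1nnn[nH]1)c1ccc(OCc2ccc3scc(-c4cc(OCCOC)ccc4C)c3c2)cc1`: 85 nM
- compound 3, `CC#C[C@@H](Cc1nnn[nH]1)c1ccc(OCc2cc(Cl)c3scc(-c4ccccc4C)c3c2)cc1`: 63 nM

All three were tested in a functional assay on cells for agonist activity at Free fatty acid receptor 1 (Homo sapiens), read by FLIPR and calcium flux; a higher number here means that more compound is needed for the effect, a lower number that less compound is needed. Compound 2 stands at the high end of these three numbers: its gap to compound 3 is within the usual scatter, while its gap to compound 1 is beyond it, so only compound 1 is clearly separated from compound 2.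

Compound 4, `CC#C[C@@H](Cc1nnn[nH]1)c1ccc(OCc2ccc3scc(-c4ccc(OCCOC)cc4C)c3c2)cc1`, has the same atoms as compound 2 joined differently: 4-(2-methoxyethoxy)-2-methylphenyl in place of 5-(2-methoxyethoxy)-2-methylphenyl on an aromatic carbon. The change keeps every group and only relocates the 2-methoxyethoxy chain around the same aromatic ring.

Going by the values given here, no step of this kind appears among the measured compounds, so there is nothing to calibrate against. Compound 4 is expected to give 70 nM, with a likely range from 25 nM to 250 nM. The expected step of a 1.2-fold lower number from compound 2 to compound 4 (0.08 log units; within the scatter) is modest and within the scatter, in either direction.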

Compound 4, half-maximal effective concentration: 9 nM
Beside the measured number, compound 4's estimate is 7.8-fold (0.89 log units) above it, and the stated range ends above it.
By their numbers in this assay, from the lowest: compounds 4 and 1 (each within the scatter of the next); then compounds 3 and 2 (each within the scatter of the next).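

In this assay, replacing 5-(2-methoxyethoxy)-2-methylphenyl with 4-(2-methoxyethoxy)-2-methylphenyl gives a 9.4-fold lower number from compound 2 to compound 4 (0.98 log units; beyond the scatter), a clear change on the aromatic carbon two ring bonds from the ring sulfur. Going by these compounds alone, both groups have the same atoms and the same counts of donors and acceptors, so this pair shows that the place of the chain on this ring alone can change the number, something the earlier compounds, with no one-place pair among them, could not show. Nothing here explains why the new place gives the lower number.

Going by these compounds, it remains open whether this effect belongs to the 2-methoxyethoxy chain itself. A plain methoxy group, a longer chain or an amine in the same place could keep the lower number or lose it.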